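The source may report more compounds than this note shows. Statements on the series, on what has been measured and on what is new or still open speak of the compounds shown alone.

Measured compounds:
compound 1, `CN(C)Cc1cccc(/C=N/Nc2ncnc3sc(C(C)(C)C)cc23)n1`, 0.381 ug/mL in a functional assay on PC-6 cells (Homo sapiens) for cytotoxicity, read by MTT assay, with a stated time of 3 days; a higher number here means a weaker inhibitor, a lower number a stronger inhibitor
compound 2, `CC(C)(C)c1cc2c(N/N=C/c3ccc(O)cc3)ncnc2s1`, > 10 ug/mL in this assay

Compound 2 stands at the limit of this assay: its reading is not a number but the ceiling of the measurement, as shown by the limit of > 10 ug/mL in this assay, at which 1 of the 2 values shown sits. Of the two measured compounds, only compound 1 has a numerical value in this assay, and compound 1 gives 0.381 ug/mL. Compound 3, `CC(C)(C)c1cc2c(N/N=C/c3ccc(CN)cc3)ncnc2s1`, has not yet been measured in this assay. It differs from compound 2 by aminomethyl in place of hydroxy on an aromatic carbon, that is, 4-hydroxyphenyl becomes 4-(aminomethyl)phenyl. For the measured compounds named here, no measured step connects these two compounds, so the size of the change in this assay must be estimated. The account expects the step from compound 2 to compound 3 to run toward stronger inhibition, beyond the scatter, as an at least 6.6-fold lower number from compound 2 to compound 3 (0.82 log units; beyond the scatter). Compound 3 is accordingly estimated at 1.5 ug/mL in this assay, within a range from 0.3 ug/mL to 10 ug/mL.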

Compound 3, half-maximal inhibitory concentration: 0.214 ug/mL
Compound 3: middle estimate off by 7.0-fold (0.85 log units), on the high side; the whole stated range lies above it.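

Until this result, the position para to a large group had shown only hydroxy, and that gave no numerical reading. Aminomethyl in place of hydroxy now gives, in this assay, an at least 46-fold lower number from compound 2 to compound 3 (1.66 log units; beyond the scatter), so this change at this position has a large effect on the reading, even though hydroxy and aminomethyl are alike in their counts of hydrogen-bond donors and acceptors. The true size of the step remains unknown because the reading of compound 2 is a limit and not a number: the limit of > 10 ug/mL in this assay, at which 1 of the 3 values shown sits.

The compounds shown cannot tell whether the added carbon or the nitrogen of aminomethyl accounts for the step. As far as these compounds go, how an amine set directly on the ring, a plain methyl or a longer aminoethyl chain would read at this position also stays open.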